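Aryl urea series: cytotoxicity on Raji cells, compound 4

This account rests on a few compounds, and the source may have more. Where it says the series, first, only, none or still open, it means among the compounds named here.

Measured so far:
compound 1 `COc1ccc(NC(=O)Nc2cc(C)nc3ccccc23)cc1` — > 25000 nM
compound 2 `Cc1cc(NC(=O)Nc2ccc(F)cc2)c2ccccc2n1` — > 25000 nM
compound 3 `Cc1cc(NC(=O)Nc2ccc(C(N)=O)cc2)c2ccccc2n1` — > 25000 nM

In an ADME assay on Raji cells (Homo sapiens) for cytotoxicity, with a stated time of 72 h (a lower number here means that less compound is needed, a higher number that more compound is needed for the effect), compound 1 gives > 25000 nM, which is a limit of the assay and not a number. Compound 2 gives > 25000 nM in this assay, again only a limit. Compound 3 gives > 25000 nM in this assay, also a limit. All three values therefore sit at the limit of > 25000 nM in this assay, at which 3 of the 3 values shown sit, and the steps among them, a step that the two limits leave unreadable from compound 1 to compound 2, a step that the two limits leave unreadable from compound 1 to compound 3 and a step that the two limits leave unreadable from compound 2 to compound 3, cannot be read in size or direction. Compound 3 thus stands where the whole series stands: at the limit, with no number of its own.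

Compound 4 `Cc1cc(NC(=O)Nc2ccc(SC(F)(F)F)cc2)c2ccccc2n1` is the next entry. Against compound 3 the change is (trifluoromethyl)sulfanyl in place of carbamoyl on an aromatic carbon. Going by the values given here, the steps that bear on this position are the three above, none of which is readable, so no size of step in this assay can be inferred from them; the only expectation the series supports is that compound 4 also reaches the limit, with an expected step of a number no higher from compound 3 to compound 4 (the limit leaves the size open). For compound 4 the estimate in this assay is 25000 nM, with a range from 8000 nM to 100000 nM.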

Compound 4, half-maximal effective concentration: 10000 nM
Compound 4: the middle estimate sits 2.5-fold (0.40 log units) above what was measured; measured number inside the range.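

Going by these compounds alone, at this aromatic carbon, (trifluoromethyl)sulfanyl gives the first readable number, so the position can affect the result in this assay: the replacements give an at least 2.5-fold lower number from compound 3 to compound 4 (0.39 log units; beyond the scatter), an at least 2.5-fold lower number from compound 2 to compound 4 (0.39 log units; beyond the scatter) and an at least 2.5-fold lower number from compound 1 to compound 4 (0.39 log units; beyond the scatter). On these data alone, all three steps start from a limit of the assay, so their full size stays open, and the steps among carbamoyl, fluoro and methoxy still cannot be read. Compound 4 is the only compound shown that stands off the limit: the limit of > 25000 nM in this assay, at which 3 of the 4 values shown sit.

As far as these compounds go, whether this shift is specific to (trifluoromethyl)sulfanyl or would also appear with a nitrile or a tert-butyl group at the same carbon remains open. Also open, from the compounds shown here alone, is whether a change on the shared core, such as an amine in place of its methyl group, would move the number further.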